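Para-fluoro on the pyrazole aryl group: compound 3

This account rests on a few compounds, and the source may have more. Where it says the series, first, only, none or still open, it means among the compounds named here.

Of the compounds shown here, two have been measured in a functional assay on HT-29 cells (Homo sapiens) for cytotoxicity, read by MTT assay, with a stated time of 72 h; on this read-out lower numbers stand for stronger inhibition and higher numbers for weaker inhibition. Compound 1 `O=C(Nc1nc2ccc(F)cc2s1)c1cn(-c2ccccc2)nc1-c1ccccc1` gives 9800 nM. Compound 2 `O=C(Nc1nc2ccc(Cl)cc2s1)c1cn(-c2ccccc2)nc1-c1ccccc1` gives 7810 nM. Among the compounds with values here, the one step between them, a 1.3-fold lower number from compound 1 to compound 2 (0.10 log units; within the scatter), is within the scatter, so compound 2 and compound 1 stand at the same level on these numbers.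

Compound 3 `O=C(Nc1nc2ccc(Cl)cc2s1)c1cn(-c2ccccc2)nc1-c1ccc(F)cc1` differs from compound 2 by fluoro in place of hydrogen on an aromatic carbon. Within the data shown here, no measured step touches this position; the only step known, from compound 1 to compound 2, concerns a halogen on the other aromatic ring and stays within the scatter. There is therefore no basis in the data for expecting a shift beyond the scatter, in either direction, in this assay.

The value of compound 3 in this assay is estimated at 7000 nM, with a range from 3000 nM to 16000 nM, which means an expected step of a 1.1-fold lower number from compound 2 to compound 3 (0.05 log units; within the scatter).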

Compound 3, half-maximal inhibitory concentration: 3320 nM
Beside the measured number, compound 3's estimate is 2.1-fold (0.32 log units) above it, and the stated range covers the measured number.
By their numbers in this assay, from the lowest: compound 3; then compounds 2 and 1 (each within the scatter of the next).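

Within the data shown here, the phenyl to 4-fluorophenyl change gives the first step that lies beyond the scatter in this assay, with a 2.4-fold lower number from compound 2 to compound 3 (0.37 log units; beyond the scatter) on a single added fluoro. This ring therefore responds to a substituent on an aromatic carbon, whereas the halogen exchange on the other aromatic ring, a 1.3-fold lower number from compound 1 to compound 2 (0.10 log units; within the scatter), stays within the scatter, although the new step is modest and rests on one pair. Nothing shown bears on why the number falls at this position.

As far as these compounds go, it remains open whether this response is specific to fluoro or would also appear with chloro, methoxy, an amine or a carboxylic acid in the same place. From the compounds shown here alone, it is also open whether the 4-fluorophenyl change would give a similar step on the core of compound 1.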